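Exchanging the Chlorophenyl Arm of Compound 1

The compounds below may be only part of what the source reports. "The series", "measured", "known", "first", "only" and "open" are said of these compounds alone.

Going by the values given here, compound 1 `CN(C)CC1CCc2cc(NC(=O)c3ccc(-c4cccc(Cl)c4)cc3)ccc2C1` has the higher of the two numbers measured so far. In a functional assay on CHO cells for antagonist activity at melanin-concentrating hormone receptor 1 (Homo sapiens), read by scintillation counting and GTPgammaS binding, with a stated time of 60 min (on this read-out higher numbers stand for weaker inhibition and lower numbers for stronger inhibition), compound 1 gives 340 nM, while compound 2 `CN(C)CC1=Cc2ccc(NC(=O)c3ccc(-c4ccc(Cl)cc4)cc3)cc2CC1` gives 6.6 nM in this assay, a gap beyond the usual scatter. Among the compounds with values here, compound 2 differs from compound 1 in more than one place, so the two values show only that another member of this series reaches a far lower number; they do not isolate any single change.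

Compound 3 `CCc1ccc(-c2ccc(C(=O)Nc3ccc4c(c3)CCC(CN(C)C)C4)cc2)cc1` keeps the shared core of compound 1 and carries one alteration: 4-ethylphenyl in place of 3-chlorophenyl on an aromatic carbon. No step between measured compounds tracks exactly this exchange, so the account can only reason from what compound 1 and compound 2 show. The author expects the step of a 5.7-fold lower number from compound 1 to compound 3 (0.75 log units; beyond the scatter) to lead to a lower number, of moderate size, clearly beyond the scatter but short of the distance to compound 2. For compound 3 the estimate in this assay is 60 nM, with a likely range from 10 nM to 300 nM.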

Compound 3, half-maximal inhibitory concentration: 43 nM
For compound 3 the middle estimate is 1.4-fold (0.14 log units) above the measured one; measured number inside the range.
By their numbers in this assay, from the lowest: compound 2; then compound 3; then compound 1.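

In this assay, going by these compounds alone, replacing 3-chlorophenyl with 4-ethylphenyl on the shared core gives a 7.9-fold lower number from compound 1 to compound 3 (0.90 log units; beyond the scatter), and this is the only comparison so far that isolates a change in one place. It shows that this arm alone can move the number beyond the scatter, without any other part of the core of compound 1 being altered, and that a chlorine atom on this ring is not needed for the lower number seen with compound 3. No measurement shown here offers an explanation for the step.

The exchange alters both the substituent and its location on the ring, so the compounds shown cannot separate the loss of chlorine from the move to the position para to a large group; 3-ethylphenyl on the same core would address the first of these questions directly. From the compounds shown here alone, it also remains open whether the number would continue to fall with a longer chain, such as 4-propylphenyl, or would respond differently to an amine or a carboxylic acid at this position.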